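Naphthalen-1-yl on the Core: Expected Acid Dissociation

This account rests on a few compounds, and the source may have more. Where it says the series, first, only, none or still open, it means among the compounds named here.

Compound 1 `COc1ccc(F)cc1CNCCCNc1ccnc2cc(Cc3cc(C)cc(C)c3)ccc12` is one of three measured compounds in this set, together with compound 2 `COc1cccc(CNCCCNc2ccnc3cc(-c4cc(C(F)(F)F)cc(C(F)(F)F)c4)ccc23)c1O` and compound 3 `Cc1cc(C)cc(Cc2ccc3c(NCCCNCc4ccco4)ccnc3c2)c1`. In a physicochemical assay for acid dissociation, compound 1 gives 9.47, compound 2 gives 9.47 and compound 3 gives 9.47, so compound 1 stands level with both at the digits shown. Within the data shown here, the one single-site step available, no change at the digits printed from compound 1 to compound 3 (within the scatter), replaces the group on a saturated chain carbon bound to an amine nitrogen and leaves the value unchanged within the scatter. Compound 4 `COc1ccc(F)cc1CNCCCNc1ccnc2cc(-c3cccc4ccccc34)ccc12` is not yet measured; it differs from compound 1 as follows: naphthalen-1-yl in place of 3,5-dimethylbenzyl on an aromatic carbon. Among the measured compounds shown here, no measured step touches this aromatic carbon of the core, and compound 2, which carries a different group there, still shows the same value as compound 1. The change is therefore expected to produce no step beyond the scatter, no change at the digits printed from compound 1 to compound 4 (within the scatter). Compound 4 is accordingly estimated at 9.47, within 9.1 to 9.8.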

Compound 4, acid dissociation constant: 9.47
For compound 4 middle estimate and measured number coincide at the digits printed; the range from low to high includes it.
By their numbers in this assay, from the lowest: compounds 1, 2, 3 and 4 (each within the scatter of the next).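

In this assay the exchange of 3,5-dimethylbenzyl for naphthalen-1-yl on an aromatic carbon of the shared core gives no change at the digits printed from compound 1 to compound 4 (within the scatter) and is the first single-site step shown at this position, since the earlier step concerned a saturated chain carbon bound to an amine nitrogen. The entering group has 10 heavy atoms and 2 six-membered aromatic rings of carbon only, against 9 heavy atoms and one such ring in the group that leaves, and this difference comes with no step beyond the scatter. Nothing measured here offers an explanation for this result.

The compounds shown leave open whether a carboxylic acid or an amine on this aromatic carbon would also stay level with compound 1 in this assay. The same question stands for a longer chain at this carbon.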